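Thiophene isomers on a dihydropyrimidinone thioester core

This account rests on a few compounds, and the source may have more. Where it says the series, first, only, none or still open, it means among the compounds named here.

Working notes. Compound 1 `CCCOC(=O)C1=C(C)NC(=O)NC1c1ccsc1` and compound 2 `CC1=C(C(=O)SC(C)C)C(c2cccs2)NC(=O)N1` share the same core; compound 3 `CC1=C(C(=O)SC(C)C)C(c2ccsc2)NC(=O)N1` is not yet measured. In an assay on membranes from HeLa cells for displacement of a labelled ligand from adenosine receptor A3 (Homo sapiens), read by scintillation counting, with a stated time of 180 min, tested at 1 uM (a higher number here means more inhibition at the concentration tested (going by the name of the read-out), a lower number less inhibition), compound 1 gives 6%, and compound 2 gives 1%, the two values lying within the scatter of each other, so neither can be called weaker. The change thiophen-3-yl in place of thiophen-2-yl on a saturated ring carbon moves from compound 2 to compound 3. Going by the values given here, no measured step of this kind exists, and compound 1 carries the entering group at a similar number, so no move beyond the scatter is expected: a number 3 percentage points higher from compound 2 to compound 3 (within the scatter). Compound 3 is estimated at 4%, with a range from -8% to 16%.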

Compound 3, a percentage reported as inhibition, at one concentration (the size of the read-out at that concentration, not a potency): 1%
Beside the measured number, compound 3's estimate is 3 percentage points above it; the measured number falls inside the stated range.
By their numbers in this assay, from the lowest: compounds 2, 3 and 1 (each within the scatter of the next).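

In this assay thiophen-3-yl in place of thiophen-2-yl on the saturated ring carbon gives no change at the digits printed from compound 2 to compound 3 (within the scatter) and so makes no readable difference at this position. With thiophen-3-yl held fixed, isopropylsulfanyl in place of propoxy on the carbonyl carbon gives a number 5 percentage points lower from compound 1 to compound 3 (within the scatter) and is not readable either. Nothing available offers an explanation for these results.

As far as these compounds go, whether any change at this position can move the read-out beyond the scatter remains open. An aminomethyl or carboxylic acid group on the thiophene, or a longer chain on the carbonyl carbon, could test this.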